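The source may hold more compounds than are shown below. What is called first, only, known or untested is meant among the compounds shown, and "the series" means these compounds.

Compound 3 `CCN(Cc1ccc(OC)cc1)Cc1c(O)ccc2c(=O)cc(C)oc12` gives 57.5 ug/mL in a functional assay on SK-OV-3 cells (Homo sapiens) for inhibition, read by sulforhodamine B assay, with a stated time of 72 h (a lower number here means a stronger inhibitor, a higher number a weaker inhibitor), the highest of the three numbers in hand. Compound 2 `COc1ccc(CN(Cc2ccccc2)Cc2c(O)ccc3c(=O)cc(C)oc23)cc1` gives 24.6 ug/mL and compound 1 `Cc1cc(=O)c2ccc(O)c(CN(Cc3ccccc3)Cc3ccccc3)c2o1` gives 19 ug/mL; the move a 1.3-fold higher number from compound 1 to compound 2 (0.11 log units; within the scatter) stays within the scatter, whereas a 2.3-fold higher number from compound 2 to compound 3 (0.37 log units; beyond the scatter) lies beyond it. Compound 4 `COc1ccc(CN(Cc2ccc([N+](=O)[O-])cc2)Cc2c(O)ccc3c(=O)cc(C)oc23)cc1` carries 4-nitrophenyl in place of methyl on a saturated chain carbon bound to an amine nitrogen, which reverses the change seen between compound 2 and compound 3 and brings a nitro substituent on the entering ring. Within the data shown here, only that one step bears on the new change, and it was modest; the nitro part of the entering group has no measured counterpart. For compound 4 a modest lower number is therefore expected, a 2.1-fold lower number from compound 3 to compound 4 (0.31 log units; beyond the scatter). Compound 4 is estimated at 28 ug/mL, range 12 ug/mL to 65 ug/mL.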

Compound 4, half-maximal inhibitory concentration: > 100 ug/mL
Compound 4 gave a limit, no number; the forecaster's own chance of this, stated with the estimate: 5%; middle value at least 3.5-fold (0.55 log units) from the limit.
By their numbers in this assay, from the lowest: compounds 1 and 2 (each within the scatter of the next); then compound 3. At a limit, above all of these: compound 4.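

In this assay compound 4 stands at a limit, not a number: the limit of > 100 ug/mL in this assay, at which 1 of the 4 values shown sits. On the amine nitrogen, an aryl group in place of methyl does not by itself bring a lower number: the nitro-bearing group gives an at least 1.7-fold higher number from compound 3 to compound 4 (0.24 log units; that floor lies within the scatter), a floor that cannot show a rise beyond the scatter. The nitro group is the sharper change, with an at least 4.0-fold higher number from compound 2 to compound 4 (0.60 log units; beyond the scatter), whereas the methoxy step gave a 1.3-fold higher number from compound 1 to compound 2 (0.11 log units; within the scatter).

As far as these compounds go, the true size of both steps stays open. So does whether an amine or a carboxylic acid in place of nitro on that ring would give a similar shift.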